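Swapping an aryl ether for an isobutyl chain on the shared core

A few compounds are considered here, and "the series" means these few. Any claim that something is new, unique, unknown or untested is made for them only; others in the source may bear on it.

Compound 1 `COc1cccc(CNCCCNc2ccnc3cc(Oc4ccc(Cl)cc4)ccc23)c1O` was examined in a physicochemical assay for solubility, with a stated time of 18 h, at pH 7.4 (a higher number here means a more soluble compound, a lower number a less soluble compound), where compound 1 gives 14500 nM. Two companions share the same core. Compound 2 `COc1cccc(Oc2ccc3c(NCCCNCc4cc(F)ccc4OC)ccnc3c2)c1` gives 14500 nM in this assay, and compound 3 `COc1ccc(F)cc1CNCCCNc1ccnc2cc(Oc3ccc(C(C)(C)C)cc3)ccc12` gives 14500 nM. Compound 1 therefore stands level with compound 2 and compound 3 at the digits recorded, and no ordering among the three can be drawn.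

Going by the values given here, the one step that joins two measured compounds by a single change, no change at the digits printed from compound 2 to compound 3 (within the scatter), replaces 3-methoxyphenyl with 4-(tert-butyl)phenyl on an oxygen on an aromatic ring and leaves the solubility unchanged within the scatter. The new compound, compound 4 `COc1cccc(CNCCCNc2ccnc3cc(CC(C)C)ccc23)c1O`, differs from compound 1 in this way: isobutyl in place of 4-chlorophenoxy on an aromatic carbon. Among the compounds with values here, no measured step touches this same position, so the step from compound 2 to compound 3 bears only loosely, as a sign that a sizeable change of substituent left this assay unmoved. The three identical readings also suggest the measured compounds may sit near a common upper reading.

On that basis compound 4 is expected to show no change beyond the scatter, no change at the digits printed from compound 1 to compound 4 (within the scatter), with an estimated solubility of 14500 nM and a likely range from 7000 nM to 29000 nM.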

Compound 4, solubility: 4200 nM
For compound 4 the middle estimate is 3.5-fold (0.54 log units) above the measured one; the whole stated range lies above it.
By their numbers in this assay, from the lowest: compound 4; then compounds 1, 2 and 3 (each within the scatter of the next).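

In this assay, this position proves able to move the read-out: isobutyl in place of 4-chlorophenoxy on an aromatic carbon gives a 3.5-fold lower number from compound 1 to compound 4 (0.54 log units; beyond the scatter), a modest step but one beyond the scatter. Going by these compounds alone, the only earlier step, no change at the digits printed from compound 2 to compound 3 (within the scatter), exchanged one aryl group on an oxygen for another, so it left an aromatic ring in place and showed no movement, whereas this change removes the oxygen and the carbon-only aromatic ring together and puts a smaller, ring-free chain in their stead; it also shows that the assay can return a number well under the level shared by the first three compounds. No measurement at hand accounts for the lower number, so the result stands as an observation only.

Because oxygen and ring leave in a single change, their shares cannot be separated: an isobutoxy group would keep the oxygen without the ring, and a phenyl group directly on the aromatic carbon would keep the ring without the oxygen. On these data alone, it also stays open whether isobutyl would give a step of similar size with the fluorinated benzyl end of compound 2.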